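Adding a Trifluoromethyl to a Dienone Side Ring

A few compounds are considered here, and "the series" means these few. Any claim that something is new, unique, unknown or untested is made for them only; others in the source may bear on it.

Of the compounds shown here, two sharing the same core have been measured so far: compound 1 `CC1=CCCC(C)(C)C1/C=C/C(=O)/C=C/c1cc(C(F)(F)F)ccc1F` and compound 2 `CC1=C(/C=C/C(=O)/C=C/c2ccccc2C(F)(F)F)C(C)(C)CCC1O`. In a functional assay on PCa 2b cells (Homo sapiens) for cytotoxicity, read by MTT assay, with a stated time of 72 h (on this read-out higher numbers stand for weaker inhibition and lower numbers for stronger inhibition), compound 1 gives 3000 nM. In this assay compound 2 gives 2900 nM, the lower of the two numbers, yet the gap to compound 1 lies within the usual scatter, so the two cannot be told apart.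

Compound 3 `CC1=C(/C=C/C(=O)/C=C/c2cc(C(F)(F)F)ccc2C(F)(F)F)C(C)(C)CCC1O` has not been measured. It differs from compound 2 by trifluoromethyl in place of hydrogen on an aromatic carbon, a further trifluoromethyl on a six-membered aromatic ring of carbon only, para to the trifluoromethyl already present. Going by the values given here, no measured pair shows this particular change, so its effect is unknown. Given the close values of compound 1 and compound 2, only a small step is expected from compound 2 to compound 3, about a 1.2-fold lower number from compound 2 to compound 3 (0.06 log units; within the scatter), in no direction beyond the scatter. Compound 3 is therefore estimated at 2500 nM, within 1000 nM to 7000 nM.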

Compound 3, half-maximal inhibitory concentration: 4000 nM
For compound 3 the middle estimate is 1.6-fold (0.20 log units) below the measured one, and the stated range covers the measured number.
By their numbers in this assay, from the lowest: compounds 2, 1 and 3 (each within the scatter of the next).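

In this assay the step to a second trifluoromethyl, on the aromatic carbon para to the trifluoromethyl group already present, is a 1.4-fold higher number from compound 2 to compound 3 (0.14 log units; within the scatter), so the two compounds cannot be told apart. Going by these compounds alone, this is the first direct reading of a change at this position, and it shows that adding this group here, with its four heavy atoms, leaves the number within what repeated measurements of one compound could give. Nothing available gives a reason for this result.

From the compounds shown here alone, what remains open is whether a different group on this same aromatic carbon, such as an amine or a carboxylic acid, would move the number beyond the scatter. This single step also cannot show whether trifluoromethyl would behave the same way on another carbon of the ring.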